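The compounds below may be only part of what the source reports. "The series", "measured", "known", "first", "only" and "open" are said of these compounds alone.

Working notes on a small set of dichloroacetamides. Compound 1 `CSc1cccc(-c2cc(NC(=O)C(Cl)Cl)cc(-c3cccc(SC)c3)c2)c1` carries two outer rings, each with a methylthio group. In a functional assay on NCI-H460 cells (Homo sapiens) for cytotoxicity, read by MTT assay, with a stated time of 68 h (on this read-out lower numbers stand for stronger inhibition and higher numbers for weaker inhibition), compound 1 gives > 30000 nM, which is a limit of the assay and not a number (the limit of > 30000 nM in this assay, at which 1 of the 3 values shown sits). Compound 3 `COc1ccc(-c2cc(NC(=O)C(Cl)Cl)cc(-c3ccc(OC)c(F)c3)c2)cc1F` carries two outer rings with methoxy and fluoro groups, and in this assay compound 3 gives 1760 nM. Compound 2 `O=C(Nc1cccc(-c2cccc(F)c2)c1)C(Cl)Cl` has a single outer ring bearing a fluoro group. In this assay compound 2 gives > 50000 nM, again only a limit (the limit of > 50000 nM in this assay, at which 1 of the 3 values shown sits). Compound 2 thus stands with compound 1 among the members for which no number was reached; only compound 3 has a number. Compound 4 `O=C(Nc1cccc(-c2ccccc2)c1)C(Cl)Cl` is not yet measured in this assay. Relative to compound 2 it shows (hydrogen in place of fluoro on an aromatic carbon). Among the measured compounds shown here, no measured pair differs in one place, so no measured step guides the expectation. No shift beyond the scatter is expected, the step being estimated at a step that the limit leaves unreadable from compound 2 to compound 4. Compound 4 is expected to give 60000 nM in this assay, within 15000 nM to 200000 nM, most likely as a limit once more.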

Compound 4, half-maximal inhibitory concentration: 20200 nM
Compound 4: the middle estimate sits 3.0-fold (0.47 log units) above what was measured; the range from low to high includes it.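

In this assay, hydrogen in place of fluoro on an aromatic carbon, meta to a large group, gives an at least 2.4-fold lower number from compound 2 to compound 4 (0.39 log units; beyond the scatter), the only one-place step shown and one beyond the scatter. With hydrogen at this place, a compound with a single outer ring reaches a measured value, so the fluoro group is not required there for a number on this read-out. The full size of the step remains unknown because compound 2 sits at a limit and not at a number: the limit of > 50000 nM in this assay, at which 1 of the 4 values shown sits.

From the compounds shown here alone, whether a chloro group, a nitrile or an amine at this place would give a lower or higher number than hydrogen remains open. Also open, going by these compounds, is whether the same change from fluoro to hydrogen would move a compound with two outer rings in the same direction.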